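The source may report more compounds than this note shows. Statements on the series, on what has been measured and on what is new or still open speak of the compounds shown alone.

Compound 1: `CCCOc1cc(C(C)(C)C)ccc1C/N=C(\S)NCc1ccc(NS(C)(=O)=O)cc1`, 250 nM. Compound 2: `CCCCOc1cc(C(C)(C)C)ccc1C/N=C(\S)NCc1ccc(NS(C)(=O)=O)cc1`, 60 nM. Compound 3: `CC(C)(C)COc1cc(C(C)(C)C)ccc1C/N=C(\S)NCc1ccc(NS(C)(=O)=O)cc1`, 60 nM.

In a functional assay for inhibition of Vanilloid receptor (Rattus norvegicus) (on this read-out higher numbers stand for weaker inhibition and lower numbers for stronger inhibition), compound 3 stands level with compound 2, and together they give the lowest numbers of the three; the gap is a 4.2-fold lower number from compound 1 to compound 3 (0.62 log units; beyond the scatter). The next compound, compound 4, is `CC(C)(C)C(=O)Oc1cc(C(C)(C)C)ccc1C/N=C(\S)NCc1ccc(NS(C)(=O)=O)cc1`, which differs from compound 3 by (tert-butyl)carbonyl in place of neopentyl on an oxygen on an aromatic ring. Within the data shown here, none of the measured steps touches a carbonyl on that oxygen: a 4.2-fold lower number from compound 1 to compound 2 (0.62 log units; beyond the scatter) and a 4.2-fold lower number from compound 1 to compound 3 (0.62 log units; beyond the scatter) changed only the saturated chain, and no change at the digits printed from compound 2 to compound 3 (within the scatter) was flat. The data therefore give no direct guide, and compound 4 is expected to land near compound 3, with a wide range, at 150 nM (40 nM to 600 nM), meaning an expected step of a 2.5-fold higher number from compound 3 to compound 4 (0.40 log units; beyond the scatter).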

Compound 4, half-maximal inhibitory concentration: 220 nM
Compound 4: the middle estimate sits 1.5-fold (0.17 log units) below what was measured, within the range that was stated.
By their numbers in this assay, from the lowest: compounds 2 and 3 (each within the scatter of the next); then compounds 4 and 1 (each within the scatter of the next).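

In this assay, among these compounds, the (tert-butyl)carbonyl group on the oxygen gives the first steps at this position toward weaker inhibition, with a 3.7-fold higher number from compound 3 to compound 4 (0.56 log units; beyond the scatter) and a 3.7-fold higher number from compound 2 to compound 4 (0.56 log units; beyond the scatter) as the two measured results. Against the propyl ether, the comparison gives a 1.1-fold lower number from compound 1 to compound 4 (0.06 log units; within the scatter) and so separates neither compound from the other. No supporting measurement bears on the reason for this loss.

Still open, from the compounds shown here alone, is whether the carbonyl or the tert-butyl part of the group governs this result. An acetyl group or a dimethylcarbamoyl group on this oxygen would bear on that question.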